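Shifting the fluorine on the phenyl ring of compound 1

The source may hold more compounds than are shown below. What is called first, only, known or untested is meant among the compounds shown, and "the series" means these compounds.

Compound 1 `COc1cc(OC)cc(N2CCN(C(=O)c3oc(C)nc3-c3cccc(F)c3)CC2)c1` carries a 3-fluorophenyl group. Among the compounds with values here, in a functional assay on HL-60 cells (Homo sapiens) for inhibition, read by MTT assay, with a stated time of 72 h (on this read-out lower numbers stand for stronger inhibition and higher numbers for weaker inhibition), compound 1 gives 28.2 nM, the only number in this small set. Compound 2 `COc1cccc(N2CCN(C(=O)c3oc(C)nc3-c3cccc(F)c3)CC2)c1` was reported in this assay as "not active" (no number reported), with no value stated. Compound 3 `COc1cc(OC)cc(N2CCN(C(=O)c3oc(C)nc3-c3ccccc3F)CC2)c1` has not been measured. It differs from compound 1 by 2-fluorophenyl in place of 3-fluorophenyl on an aromatic carbon. Within the data shown here, no measured step of this kind is available, so the expectation is a change within the usual scatter, with a slight lean toward weaker inhibition, a step from a 1.4-fold higher number from compound 1 to compound 3 (0.15 log units; within the scatter). Compound 3 is therefore expected at about 40 nM, within 12 nM to 150 nM.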

Compound 3, half-maximal inhibitory concentration: 10.3 nM
Beside the measured number, compound 3's estimate is 3.9-fold (0.59 log units) above it, and the stated range ends above it.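

The place of the fluorine on the phenyl ring matters in this assay, even though the two compounds have the same atoms. Taking 2-fluorophenyl in place of 3-fluorophenyl gives a 2.7-fold lower number from compound 1 to compound 3 (0.44 log units; beyond the scatter) and this modest step lies beyond the scatter. Within the data shown here, it is the first readable step in this set, and nothing measured here accounts for it.

On these data alone, it remains open whether the fluorine itself is needed, which plain phenyl would test. Also open, as far as these compounds go, is how a chlorine or a methyl group in the fluorine's place would compare.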